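Chloro for Bromo: Expected Cytotoxicity of Compound 4

The compounds below may be only part of what the source reports. "The series", "measured", "known", "first", "only" and "open" are said of these compounds alone.

Of the compounds shown here, three sharing one core have been tested in a functional assay on HepG2 cells (Homo sapiens) for cytotoxicity, read by MTT assay, with a stated time of 24 h; a higher number here means a weaker inhibitor, a lower number a stronger inhibitor. Compound 1 `O=C(Nc1ccc(C(F)(F)F)cc1)c1cc(Br)ccc1O` gives 5500 nM. Compound 2 `CC(=O)c1ccc(NC(=O)c2cc(Br)ccc2O)cc1` gives 15900 nM, and compound 3 `C/C(=N\OCC(=O)N[C@H](C(=O)N[C@@H](CCCCN)C(=O)N1CCC[C@H]1C(=O)N[C@@H](CCCCN)C(=O)NCC(=O)O)[C@@H](C)O)c1ccc(NC(=O)c2cc(Br)ccc2O)cc1` gives 191000 nM. Compound 2 therefore stands second highest of the three numbers: the step of a 2.9-fold higher number from compound 1 to compound 2 (0.46 log units; beyond the scatter) is beyond the scatter, and compound 3 sits much farther away, its number being far higher than that of compound 2.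

Compound 4 `CC(=O)c1ccc(NC(=O)c2cc(Cl)ccc2O)cc1` is the compound still to be measured. It differs from compound 2 in a single place: chloro in place of bromo on an aromatic carbon. Among the steps measured so far, only a 2.9-fold higher number from compound 1 to compound 2 (0.46 log units; beyond the scatter) exists, and it concerns a different group on the core, not the halogen. Among the compounds with values here, no measured pair of compounds shows what swapping one halogen for another does here, so there is nothing in the data that would point to a large shift in either direction. Compound 4 is therefore expected to land close to compound 2, with the step of a 1.0-fold higher number from compound 2 to compound 4 (0.00 log units; within the scatter) expected to stay within the scatter. The estimate for compound 4 is 16000 nM, with a range from 6000 nM to 45000 nM.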

Compound 4, half-maximal inhibitory concentration: 7900 nM
The estimate for compound 4 lay 2.0-fold (0.31 log units) above the measured number; the range from low to high includes it.
By their numbers in this assay, from the lowest: compounds 1, 4 and 2 (each within the scatter of the next, the first and the last beyond it); then compound 3.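

In this assay, within the data shown here, the only other single-place step on record, a 2.9-fold higher number from compound 1 to compound 2 (0.46 log units; beyond the scatter), exchanges trifluoromethyl for acetyl and leaves the halogen untouched, so the carbon para to a hydroxy group is tested here for the first time. With chloro in place of bromo at that carbon, the result is a 2.0-fold lower number from compound 2 to compound 4 (0.30 log units; within the scatter), which means that this one pair shows no difference between the two halogens that can be told apart from the ordinary spread of repeated measurements. No measurement of any property is at hand that could explain this result.

This single swap between two halogens says little about how far the position accepts other groups, and an amine, a carboxylic acid or a longer chain on the same carbon could give a very different number. From the compounds shown here alone, it also remains open whether chloro and bromo would again be indistinguishable in a compound carrying trifluoromethyl in place of acetyl.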